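Hemolysis inhibition in a trimethoxychalcone pair and a third analogue

A few compounds are considered here, and "the series" means these few. Any claim that something is new, unique, unknown or untested is made for them only; others in the source may bear on it.

Measured so far:
compound 1 `COc1cc(OC)c(OC)cc1/C=C/C(=O)c1cc(Cl)ccc1O` gives 2.23 ug/mL
compound 2 `COc1cc(OC)c(OC)cc1/C=C/C(=O)c1cc(O)ccc1O` gives 2.1 ug/mL

Both numbers come from a functional assay on cells (Erythrocyte, Rattus norvegicus) for inhibition, read by hemolysis, with a stated time of 1 h; on this read-out lower numbers stand for stronger inhibition and higher numbers for weaker inhibition. Compound 1 has the higher of the two numbers, and its nearest neighbour is compound 2, reached by a 1.1-fold lower number from compound 1 to compound 2 (0.03 log units; within the scatter), so the two compounds read the same within scatter.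

Compound 3 `COc1cc(OC)c(OC)cc1/C=C/C(=O)c1ccc(Cl)cc1` has not yet been measured in this assay. It differs from compound 1 in one place: 4-chlorophenyl in place of 5-chloro-2-hydroxyphenyl on a carbonyl carbon. For the measured compounds named here, no measured step bears directly on this change; the single known step concerns a hydroxy in place of chloro on the aromatic carbon and stayed within scatter, which says nothing about removing the hydroxy together with a shift of the chloro on the ring that sits on the carbonyl carbon. The expected step is therefore a 1.6-fold higher number from compound 1 to compound 3 (0.20 log units; within the scatter), without a grounded direction. For compound 3 the estimated value in this assay is 3.5 ug/mL, with a range from 1.2 ug/mL to 10 ug/mL.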

Compound 3, half-maximal inhibitory concentration: 2.3 ug/mL
Beside the measured number, compound 3's estimate is 1.5-fold (0.18 log units) above it; the measured number falls inside the stated range.
By their numbers in this assay, from the lowest: compounds 2, 1 and 3 (each within the scatter of the next).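

In this assay, 4-chlorophenyl in place of 5-chloro-2-hydroxyphenyl on the carbonyl carbon gives a 1.0-fold higher number from compound 1 to compound 3 (0.01 log units; within the scatter) and 4-chlorophenyl in place of 2,5-dihydroxyphenyl gives a 1.1-fold higher number from compound 2 to compound 3 (0.04 log units; within the scatter) in the same read-out. The earlier pair only exchanged chloro for hydroxy, whereas here the hydroxy of compound 1 is gone and the chloro sits elsewhere on the ring, yet all three compounds still read alike within scatter, so a hydroxy on this ring is not required for the read-out seen here. Nothing on hand gives a reason for this flat result.

Open, on these data alone, is whether the flat read-out holds when an amine or a carboxylic acid sits on this ring. Also open, as far as these compounds go, is whether a plain phenyl on the carbonyl carbon, with neither chloro nor hydroxy, would read the same as compound 3.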